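The source may report more compounds than this note shows. Statements on the series, on what has been measured and on what is new or still open speak of the compounds shown alone.

Of the compounds shown here, three that share a common core have been measured in a functional assay on CCRF-CEM cells (Homo sapiens) for cytotoxicity, read by MTT assay, with a stated time of 72 h; a higher number here means a weaker inhibitor of growth, a lower number a stronger inhibitor of growth. Compound 1 `COc1ccc(OC(=O)Nc2ccc([Se]C#N)cc2)cc1` gives 41500 nM in this assay. Compound 2 `CCCOC(=O)Nc1ccc([Se]C#N)cc1` gives 38400 nM. Compound 3 `O=C(Nc1ccc([Se][Se]c2ccc(NC(=O)OCc3ccccc3)cc2)cc1)OCc1ccccc1` gives 34600 nM. Compound 2 thus sits among three numbers that all lie within the usual scatter of one another, so none of the three can be called stronger or weaker than the others on this evidence. Compound 4 `CCCCOC(=O)Nc1ccc([Se]C#N)cc1` has not yet been measured. It differs from compound 2 by methyl in place of hydrogen on a saturated chain carbon, three bonds along the chain from an oxygen next to a carbonyl group. Going by the values given here, no measured pair among the three compounds shows a step of this kind, so the expected step from compound 2 to compound 4 is a 1.0-fold lower number from compound 2 to compound 4 (0.00 log units; within the scatter), nothing beyond the scatter. Compound 4 is therefore estimated at 38000 nM, with a range from 19000 nM to 76000 nM.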

Compound 4, concentration for total growth inhibition: 27900 nM
Compound 4: the middle estimate sits 1.4-fold (0.13 log units) above what was measured; low and high end bracket the measured number.
By their numbers in this assay, from the lowest: compounds 4, 3, 2 and 1 (each within the scatter of the next).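

Methyl in place of hydrogen on a saturated chain carbon, three bonds along the chain from an oxygen next to a carbonyl group, turns propyl into butyl and gives in this assay a 1.4-fold lower number from compound 2 to compound 4 (0.14 log units; within the scatter). Going by these compounds alone, this is the first step read at this position, and it shows that this added carbon leaves the number within the scatter. No evidence is available to explain the result. From the compounds shown here alone, whether a longer chain such as hexyl, or an amine or a carboxylic acid in place of butyl, would move the number beyond the scatter stays open. One step also cannot establish a trend along the chain.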